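A few compounds are considered here, and "the series" means these few. Any claim that something is new, unique, unknown or untested is made for them only; others in the source may bear on it.

Of the compounds shown here, three built on one shared core have been measured in a functional assay on HepG2 cells (Homo sapiens) for antiproliferative activity, read by MTT assay, with a stated time of 3 days; on this read-out higher numbers stand for weaker inhibition and lower numbers for stronger inhibition. Compound 1 `Cc1ccc(C#Cc2cn(C/C=C\CN3C(=O)c4ccccc4C3=O)c(=O)[nH]c2=O)cc1` gives 68000 nM, compound 2 `CCCCCCCCC#Cc1cn(C/C=C\CN2C(=O)c3ccccc3C2=O)c(=O)[nH]c1=O` gives 39000 nM, and compound 3 `CCCCCc1ccc(C#Cc2cn(C/C=C\CN3C(=O)c4ccccc4C3=O)c(=O)[nH]c2=O)cc1` gives 18000 nM, the lowest of the three numbers; the steps of a 3.8-fold lower number from compound 1 to compound 3 (0.58 log units; beyond the scatter) and a 2.2-fold lower number from compound 2 to compound 3 (0.34 log units; beyond the scatter) lie beyond the scatter, whereas a 1.7-fold lower number from compound 1 to compound 2 (0.24 log units; within the scatter) does not. Compound 4 `CCCCC#Cc1cn(C/C=C\CN2C(=O)c3ccccc3C2=O)c(=O)[nH]c1=O` differs from compound 3 by butyl in place of 4-pentylphenyl on a triple-bonded carbon. Within the data shown here, the steps that bear on this change are a 2.2-fold lower number from compound 2 to compound 3 (0.34 log units; beyond the scatter) and a 3.8-fold lower number from compound 1 to compound 3 (0.58 log units; beyond the scatter), both of which lowered the number when the group on that carbon was exchanged or extended; the present change runs the other way. Compound 4 is therefore expected to show the step of a 3.3-fold higher number from compound 3 to compound 4 (0.52 log units; beyond the scatter). Compound 4 is estimated at 60000 nM, within a range from 25000 nM to 150000 nM.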

Compound 4, half-maximal inhibitory concentration: 17000 nM
Compound 4: the middle estimate sits 3.5-fold (0.55 log units) above what was measured; measured number below the stated range.
By their numbers in this assay, from the lowest: compounds 4 and 3 (each within the scatter of the next); then compounds 2 and 1 (each within the scatter of the next).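

At this triple-bonded carbon in this assay, butyl, with far fewer heavy atoms and no ring, serves as well as 4-pentylphenyl, a 1.1-fold lower number from compound 3 to compound 4 (0.02 log units; within the scatter), so the aromatic ring is not required for the lowest numbers seen here. Butyl also improves on octyl, a 2.3-fold lower number from compound 2 to compound 4 (0.36 log units; beyond the scatter), and on 4-methylphenyl, a 4.0-fold lower number from compound 1 to compound 4 (0.60 log units; beyond the scatter). The same butyl extension acts in opposite directions on the two cores: the same change on two cores in this assay, a 3.8-fold lower number (0.58 log units; beyond the scatter) from compound 1 to compound 3 and a 2.3-fold higher number (0.36 log units; beyond the scatter) from compound 4 to compound 2, 8.7-fold (0.94 log units) apart, beyond the scatter of two such steps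

The compounds shown leave open whether a shorter chain such as propyl, or an amine at the end of the butyl chain, would hold this level.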